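The source may hold more compounds than are shown below. What is called first, only, known or untested is meant among the compounds shown, and "the series" means these compounds.

Values so far in a functional assay on MCF7 cells (Homo sapiens) for cytotoxicity, read by MTT assay, with a stated time of 48 h; on this read-out lower numbers stand for stronger inhibition and higher numbers for weaker inhibition
- compound 1 `O=[N+]([O-])c1ccc2[nH]c(CSCc3nc4cc([N+](=O)[O-])ccc4[nH]3)nc2c1` at 1740 nM
- compound 2 `O=C(CSCc1nc2cc([N+](=O)[O-])ccc2[nH]1)c1ccccc1` at 18600 nM

Compound 2 (18600 nM) holds the higher of the two numbers. Set against compound 1 (1740 nM), the gap lies beyond the scatter. Compound 3 `NC(=O)CSCc1nc2cc([N+](=O)[O-])ccc2[nH]1` keeps the rest of compound 2 and has amino in place of phenyl on a carbonyl carbon. Among the compounds with values here, no measured step between compounds differing in one place is available, so the expectation is loose: a small rise in the number in this assay, not clearly beyond the scatter. That expectation is estimated here as a single step (a 1.3-fold higher number from compound 2 to compound 3 (0.13 log units; within the scatter)). For compound 3 the expected value is 25000 nM (estimated range 6000 nM to 90000 nM).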

Compound 3, half-maximal inhibitory concentration: 19700 nM
Compound 3: the middle estimate sits 1.3-fold (0.10 log units) above what was measured, within the range that was stated.
By their numbers in this assay, from the lowest: compound 1; then compounds 2 and 3 (each within the scatter of the next).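

In this assay, amino in place of phenyl on a carbonyl carbon gives a 1.1-fold higher number from compound 2 to compound 3 (0.02 log units; within the scatter) at this position. The number here thus does not depend on keeping the six-membered aromatic ring of carbon only: a single nitrogen in its place gives a value within the scatter. No measured evidence on either group bears on this result.

Still open, from the compounds shown here alone, is whether a carboxylic acid, a dimethylamino group or a longer chain on the same carbonyl carbon would also stay within the scatter of compound 3.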